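The source may report more compounds than this note shows. Statements on the series, on what has been measured and on what is new or still open speak of the compounds shown alone.

Three compounds built on a shared core open this account, and none of them yet gives a number. In an ADME assay on THP-1 cells (Homo sapiens) for cytotoxicity, read by MTT assay, with a stated time of 72 h (a lower number here means that less compound is needed, a higher number that more compound is needed for the effect), compound 1 `Cc1cc(-c2ccc3[nH]c(=O)nc(-c4ccccc4)c3c2)ccn1` gives > 50000 nM, which is a limit of the assay. Compound 2 `Cc1cncc(-c2ccc3[nH]c(=O)nc(-c4ccccc4)c3c2)c1` gives > 50000 nM, again a limit. Compound 3 `N#Cc1ccc(-c2ccc3[nH]c(=O)nc(-c4ccccc4)c3c2)cc1` gives > 50000 nM, also a limit and not a number, so its place among the others cannot be ranked. For the measured compounds named here, the series so far rests on (the limit of > 50000 nM in this assay, at which 3 of the 3 values shown sit).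

The next compound, compound 4 `O=c1nc(-c2ccccc2)c2cc(-c3cc[nH]n3)ccc2[nH]1`, carries 1H-pyrazol-3-yl in place of 4-cyanophenyl on an aromatic carbon. Going by the values given here, three measured steps bear on this change, each a swap of one aromatic group for another on an aromatic carbon. They are a step that the two limits leave unreadable from compound 1 to compound 3, a step that the two limits leave unreadable from compound 2 to compound 3 and a step that the two limits leave unreadable from compound 1 to compound 2. None of them offers a size or a direction to carry over, and the new group has not been tried in this assay. The expectation therefore starts from the limit of compound 3, > 50000 nM, and allows only for a modest move towards less compound being needed. The expected step is an at least 1.1-fold lower number from compound 3 to compound 4 (0.04 log units; that floor lies within the scatter). For compound 4 the estimated value is 45000 nM, with an expected range from 15000 nM to 70000 nM.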

Compound 4, half-maximal effective concentration: > 50000 nM
Compound 4: a limit, no number; the forecaster's own chance of this, stated with the estimate: 70%; at least 1.1-fold (0.04 log units) between middle value and limit.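

In this assay compound 4 also stops at a limit, so its steps from compound 1, compound 2 and compound 3 cannot be read in size or direction. The series still rests on a single limit: the limit of > 50000 nM in this assay, at which 4 of the 4 values shown sit. The compounds shown leave open whether any aromatic group at this place on the shared core gives a number at all.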